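From bromo to trifluoromethyl: estimating compound 4

The compounds below may be only part of what the source reports. "The series", "measured", "known", "first", "only" and "open" are said of these compounds alone.

- Compound 1 `COc1cc(Cl)ccc1C(=S)Nc1ccc(C(F)(F)F)cc1O`: 3140 nM
- Compound 2 `COc1ccc(Cl)cc1C(=S)Nc1ccc(Cl)cc1O`: 4450 nM
- Compound 3 `COc1ccc(Cl)cc1C(=S)Nc1ccc(Br)cc1O`: 7600 nM

All three compounds were tested in a functional assay on HepG2 cells (Homo sapiens) for cytotoxicity, with a stated time of 24 h; on this read-out lower numbers stand for stronger inhibition and higher numbers for weaker inhibition. In this small set, compound 3 at 7600 nM cannot be separated from compound 2, while compound 1 gives a lower number, and that gap lies beyond the scatter.

The next compound is compound 4 `COc1ccc(Cl)cc1C(=S)Nc1ccc(C(F)(F)F)cc1O`. It differs from compound 3 at a single place, with trifluoromethyl in place of bromo on an aromatic carbon. Within the data shown here, the only measured step at this place is a 1.7-fold higher number from compound 2 to compound 3 (0.23 log units; within the scatter), with bromo in place of chloro, and it does not separate those two compounds. Among the measured compounds shown here, no measured step shows the change from bromo to trifluoromethyl directly. Compound 1 also carries trifluoromethyl and gives 3140 nM, but it differs from compound 4 in where its chloro stands, so it is only a loose guide.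

Taken together, these numbers point to a modest move toward a lower number, no larger than the scatter. The expected step is a 1.7-fold lower number from compound 3 to compound 4 (0.23 log units; within the scatter). For compound 4 the estimated value is 4500 nM, with an expected range from 2000 nM to 9500 nM.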

Compound 4, half-maximal inhibitory concentration: 3690 nM
Beside the measured number, compound 4's estimate is 1.2-fold (0.09 log units) above it, within the range that was stated.
By their numbers in this assay, from the lowest: compounds 1, 4, 2 and 3 (each within the scatter of the next, the first and the last beyond it).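

In this assay, among these compounds, the change from bromo to trifluoromethyl gives a 2.1-fold lower number from compound 3 to compound 4 (0.31 log units; beyond the scatter) and is the first step at this place that lies beyond the scatter, although it remains modest. The same group in place of chloro gives a 1.2-fold lower number from compound 2 to compound 4 (0.08 log units; within the scatter) and this small difference means that trifluoromethyl and chloro cannot be separated here, just as chloro and bromo could not be, so only the two ends of this short series, bromo and trifluoromethyl, stand apart. The larger trifluoromethyl group therefore brings no rise in the number at this place, but the data offer no measured explanation for the step from bromo.

Among the compounds shown here, with only three groups compared at this place, and all of them giving numbers in a narrow span, it remains open whether the number would stay there with a plain hydrogen, a methoxy group, an amine or a carboxylic acid in the same spot. A longer chain such as propyl would show how much more bulk this place accepts before the number changes clearly.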